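A few compounds are considered here, and "the series" means these few. Any claim that something is new, unique, unknown or untested is made for them only; others in the source may bear on it.

Values in a functional assay on A549 cells (Homo sapiens) for antiproliferative activity, read by MTT assay, with a stated time of 72 h; a lower number here means a stronger inhibitor of growth, a higher number a weaker inhibitor of growth:
Compound 1 `Cc1c(C(=O)Nc2ccc(SC#N)cc2)nnn1-c1ccc(C(C)C)cc1`: > 100000 nM (a limit)
Compound 2 `Cc1ccc(-n2nnc(C(=O)Nc3ccc(SC#N)cc3)c2C)cc1C`: > 100000 nM (a limit)

Neither compound has yet given a number in this assay. The record so far is the limit of > 100000 nM in this assay, at which 2 of the 2 values shown sit. Compound 2 therefore stands only at a limit, > 100000 nM. Among the compounds with values here, the one measured step is a step that the two limits leave unreadable from compound 1 to compound 2, and it offers no size to carry forward.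

Compound 3 `Cc1ccc(Cl)cc1-n1nnc(C(=O)Nc2ccc(SC#N)cc2)c1C` carries 5-chloro-2-methylphenyl in place of 3,4-dimethylphenyl on an aromatic nitrogen. Within the data shown here, the only comparable measured change is the step from compound 1 to compound 2, which also exchanged the group on that nitrogen but cannot be sized. No firm direction can therefore be expected in this assay, and the expectation is that compound 3 stays close to the limit of compound 2. The expected step is an at least 1.2-fold lower number from compound 2 to compound 3 (0.09 log units; that floor lies within the scatter). For compound 3 the estimated value is 80000 nM, with an expected range from 15000 nM to 200000 nM.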

Compound 3, concentration for 50% growth inhibition: > 100000 nM
Compound 3: a limit, no number; the forecaster's own chance of this, stated with the estimate: 65%; middle value at least 1.2-fold (0.09 log units) from the limit.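

Compound 3 gives > 100000 nM in this assay, which is a limit and not a number. Within the data shown here, no step among compound 1, compound 2 and compound 3 can be read. The compounds shown leave open whether any group on that nitrogen gives a measurable growth inhibition, since the record so far is a single ceiling: the limit of > 100000 nM in this assay, at which 3 of the 3 values shown sit.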